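A few compounds are considered here, and "the series" means these few. Any claim that something is new, unique, unknown or untested is made for them only; others in the source may bear on it.

Of the compounds shown here, three sharing one core have been measured in an ADME assay on a cell-free system (plasma, Rattus norvegicus) for protein binding. In this assay, compound 1 `CNc1nccc(N2CC[C@H](NC(=O)Nc3ccc(CN(C)C)c(C(F)(F)F)c3)C2)n1` gives 91%, compound 2 `CNc1nccc(N2CC[C@H](NC(=O)Nc3cc(OC)cc(OC)c3)C2)n1` gives 96.7% and compound 3 `CNc1nccc(N2CC[C@H](NC(=O)Nc3cccc(C#N)c3)C2)n1` gives 91.6%. The values of compound 3 and compound 1 lie within the scatter of each other, so the two stand level. Compound 2 has less unbound compound than compound 3, and that gap lies beyond the scatter.

Compound 4 `CNc1nccc(N2CC[C@H](NC(=O)Nc3ccc(C)c(Cl)c3)C2)n1` keeps the core and carries 3-chloro-4-methylphenyl in place of 3-cyanophenyl on an amide-type nitrogen. Going by the values given here, no measured pair isolates this exchange, so any forecast rests on thin evidence. Compound 2, at 96.7%, shows that a group without the nitrile can sit with far less of the compound free. Compound 1, at 91%, goes against that reading, as it also lacks the nitrile yet stands level with compound 3.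

The expected change is a moderate move towards more binding and less free compound, probably just beyond the scatter, and it is estimated as a 2.1-fold lower unbound fraction from compound 3 to compound 4 (0.32 log units; beyond the scatter). For compound 4 the expected value is 96%, with an estimated range from 92% to 98.5%.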

Compound 4, plasma protein binding: 98.9%
The estimate for compound 4 lay 3.6-fold (0.56 log units) (unbound fraction) above the measured number, and the stated range ends below it.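

In this assay, going by these compounds alone, the exchange of 3-cyanophenyl for 3-chloro-4-methylphenyl on the amide-type nitrogen gives a 7.6-fold lower unbound fraction from compound 3 to compound 4 (0.88 log units; beyond the scatter) and is the first step at this position that isolates a single exchange, showing that this aryl group alone can shift the balance between bound and free compound. The shift appears even though the two groups have the same number of heavy atoms and the same six-membered aromatic ring of carbon only; what the structural comparison shows changing is that a nitrile with its hydrogen-bond acceptor leaves, while a chlorine and a methyl enter. Nothing available here explains why the free fraction falls so far.

Going by these compounds, the step changes three things at once, so it remains open whether the loss of the nitrile, the arrival of the chlorine or the arrival of the methyl accounts for it, and 3-chlorophenyl or 4-methylphenyl at the same place would begin to separate them. On these data alone, how binding would respond to a carboxylic acid or a morpholine on this phenyl ring also remains open.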